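The source may hold more compounds than are shown below. What is called first, only, known or untested is meant among the compounds shown, and "the series" means these compounds.

Measured in an ADME assay on HUVEC cells (Homo sapiens) for cytotoxicity, read by MTT assay, with a stated time of 24 h; on this read-out higher numbers stand for lower toxicity in this test and lower numbers for higher toxicity in this test:
- compound 1 `Brc1cccc(/C=C/c2nnc(-c3ccc4c(c3)OCCO4)o2)c1`: 322000 nM
- compound 2 `O=[N+]([O-])c1ccccc1/C=C/c1nnc(-c2ccc3c(c2)OCCO3)o1`: 323000 nM
- compound 3 `Fc1ccccc1/C=C/c1nnc(-c2ccc3c(c2)OCCO3)o1`: 402000 nM

Compound 3, at 402000 nM, sits within the scatter of both other compounds, so the three values show no order among themselves.

The next change leads to compound 4 `Clc1ccc(/C=C/c2nnc(-c3ccc4c(c3)OCCO4)o2)cc1`, with 4-chlorophenyl in place of 2-fluorophenyl on a double-bonded chain carbon bound to a double-bonded chain carbon.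

Going by the values given here, two measured steps bear on this change, since both alter what the phenyl group carries: a 1.2-fold higher number from compound 1 to compound 3 (0.10 log units; within the scatter) and a 1.2-fold higher number from compound 2 to compound 3 (0.10 log units; within the scatter). Both are small and within the scatter. Among the compounds with values here, no 4-chlorophenyl compound has been measured yet, so this rests on three compounds only.

No step beyond the scatter is therefore expected in this assay. The expected step is a 1.1-fold lower number from compound 3 to compound 4 (0.06 log units; within the scatter). The estimate for compound 4 is 350000 nM, with an expected range from 200000 nM to 600000 nM.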

Compound 4, half-maximal cytotoxic concentration: 312000 nM
Compound 4: the middle estimate sits 1.1-fold (0.05 log units) above what was measured; the measured number falls inside the stated range.
By their numbers in this assay, from the lowest: compounds 4, 1, 2 and 3 (each within the scatter of the next).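

Within this assay, 4-chlorophenyl at this place gives a 1.3-fold lower number from compound 3 to compound 4 (0.11 log units; within the scatter) and a 1.0-fold lower number from compound 1 to compound 4 (0.01 log units; within the scatter), so this group also shows no step beyond the scatter. The series now covers chloro as well as fluoro, bromo and nitro on the phenyl group, and compounds 1, 2, 3 and 4 remain inseparable, with no order among them in this test. No measured evidence accounts for this flat result.

From the compounds shown here alone, whether the flat result holds for other kinds of group on this phenyl ring, such as an amine or a carboxylic acid, remains open, as does the effect of a longer chain in place of the phenyl group. The shared core is constant throughout, so the compounds shown say nothing about a change there.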